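Sulfonyl swap from isopropyl to dimethylamino

A few compounds are considered here, and "the series" means these few. Any claim that something is new, unique, unknown or untested is made for them only; others in the source may bear on it.

In a functional assay on BXPC-3 cells (Homo sapiens) for inhibition, read by MTT assay, with a stated time of 7 days (a higher number here means a weaker inhibitor, a lower number a stronger inhibitor), compound 3 (`CC(C)S(=O)(=O)c1ccc(S(=O)(=O)N2CCC[C@@H](C(=O)N3CCC(F)(F)CC3)C2)cc1`) gives 50 nM, the lowest number of the three measured. Compound 1 (`O=C([C@@H]1CCCN(S(=O)(=O)c2ccc(S(=O)(=O)N3CC[C@@H](O)C3)cc2)C1)N1CCC(F)(F)CC1`) gives 330 nM and compound 2 (`O=C([C@@H]1CCCN(S(=O)(=O)c2ccc(S(=O)(=O)C3COC3)cc2)C1)N1CCC(F)(F)CC1`) gives 361 nM.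

Compound 4 (`CN(C)S(=O)(=O)c1ccc(S(=O)(=O)N2CCC[C@@H](C(=O)N3CCC(F)(F)CC3)C2)cc1`) has dimethylamino in place of isopropyl on a sulfonyl sulfur. Three measured steps change the same place: a 6.6-fold lower number from compound 1 to compound 3 (0.82 log units; beyond the scatter) and a 7.2-fold lower number from compound 2 to compound 3 (0.86 log units; beyond the scatter), both modest and beyond the scatter, and a 1.1-fold higher number from compound 1 to compound 2 (0.04 log units; within the scatter), within it. Going by the values given here, no measured compound carries dimethylamino, so the evidence is indirect. Compound 1, with its 3-hydroxypyrrolidin-1-yl group, is the closest guide, and its step of a 6.6-fold lower number from compound 1 to compound 3 (0.82 log units; beyond the scatter) suggests a partial reversal. A higher number is expected, with an estimated step of a 2.4-fold higher number from compound 3 to compound 4 (0.38 log units; beyond the scatter). The estimate for compound 4 is 120 nM, with an expected range of 40 nM to 350 nM.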

Compound 4, half-maximal inhibitory concentration: 560 nM
For compound 4 the middle estimate is 4.7-fold (0.67 log units) below the measured one; measured number outside the range, above it.
By their numbers in this assay, from the lowest: compound 3; then compounds 1, 2 and 4 (each within the scatter of the next).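

In this assay the sulfonyl sulfur proves sensitive even to a swap between two groups of 3 heavy atoms, with an 11-fold higher number from compound 3 to compound 4 (1.05 log units; beyond the scatter) as a large step. Dimethylamino gives no separation from the other two groups, with a 1.6-fold higher number from compound 2 to compound 4 (0.19 log units; within the scatter) and a 1.7-fold higher number from compound 1 to compound 4 (0.23 log units; within the scatter) both within the scatter, so among the four compounds only compound 3 stands apart. No evidence here accounts for the gap between isopropyl and dimethylamino.

Going by these compounds, whether the lower number needs an all-carbon group on the sulfonyl sulfur stays open. Ethyl, cyclopropyl or tert-butyl there would test this.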